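The source may hold more compounds than are shown below. What is called first, only, known or untested is meant among the compounds shown, and "the series" means these compounds.

Three compounds have been run through an ADME assay on microsomes from liver (Rattus norvegicus, strain Wistar) for metabolic stability, tested at 2.5 uM; a lower number here means slower removal, a higher number faster removal of the compound. Compound 1 `Clc1ccc(-c2ccc(Cn3nnc4ccccc43)cn2)cc1` gives 1 mL/min/g, compound 2 `Fc1cc(Cl)ccc1-c1ccc(Cn2nnc3c(F)cccc32)cn1` gives 0.6 mL/min/g, and compound 3 `Brc1cccc2c1nnn2CC1CCCC1` gives 14.6 mL/min/g, the highest of the three numbers, standing beyond the scatter from both compound 1 and compound 2. No pair among these three differs in a single place, so their gaps are simply what the numbers show. Compound 4 `CCCn1nnc2c(Br)cccc21` has not yet been measured; it differs from compound 3 by ethyl in place of cyclopentyl on a saturated chain carbon bound to an aromatic nitrogen. Within the data shown here, no measured step of this kind exists to lean on, so the expected change a 2.4-fold lower number from compound 3 to compound 4 (0.39 log units; beyond the scatter) is a moderate fall in this assay, though a step within the scatter is also plausible. Compound 4 is thus estimated at 6 mL/min/g, with a range from 2 mL/min/g to 15 mL/min/g.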

Compound 4, intrinsic clearance in a liver preparation (reported as CLH), per the amount of preparation that the assay uses: 0.8 mL/min/g
For compound 4 the middle estimate is 7.5-fold (0.88 log units) above the measured one; the measured number lies below the stated range.
By their numbers in this assay, from the lowest: compounds 2, 4 and 1 (each within the scatter of the next); then compound 3.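

In this assay, the group on a saturated chain carbon bound to an aromatic nitrogen proves decisive for the number: ethyl in place of cyclopentyl gives an 18-fold lower number from compound 3 to compound 4 (1.26 log units; beyond the scatter). Among these compounds, this is the first single-place step in the set, and it removes the non-aromatic ring along with part of the carbon count. Nothing measured here explains the size of this fall.

The compounds shown leave open whether the ring itself or only the size of the group carries the step. A cyclopropyl ring or a longer chain such as butyl at this place would separate the two.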